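The source may hold more compounds than are shown below. What is called first, only, known or untested is meant among the compounds shown, and "the series" means these compounds.

In a functional assay on HCT-116 cells (Homo sapiens), read by MTT assay, with a stated time of 72 h (a higher number here means a weaker inhibitor, a lower number a stronger inhibitor), compound 1, whose structure is `COc1ncnc2c1c(-c1cccs1)cn2[C@@H]1O[C@H](CO)[C@@H](O)[C@H]1O`, gives 440 nM. Among the three values shown it is the only one that is a number, the other two being assay limits. Compound 2, with structure `COc1nc(N)nc2c1c(-c1cccs1)cn2[C@@H]1O[C@H](CO)[C@@H](O)[C@H]1O`, reaches only the assay limit of > 20000 nM. Compound 3, with structure `Cc1ncnc2c1c(-c1cccs1)cn2[C@@H]1O[C@H](CO)[C@@H](O)[C@H]1O`, likewise reaches only the assay limit of > 20000 nM. The two measured steps are an at least 45-fold higher number from compound 1 to compound 2 (1.65 log units; beyond the scatter) and an at least 45-fold higher number from compound 1 to compound 3 (1.65 log units; beyond the scatter), so that both changes away from compound 1 end at the limit of > 20000 nM in this assay, at which 2 of the 3 values shown sit.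

Compound 4, with structure `COc1ncnc2c1c(-c1cc3ccccc3o1)cn2[C@@H]1O[C@H](CO)[C@@H](O)[C@H]1O`, differs from compound 1 by 1-benzofuran-2-yl in place of thiophen-2-yl on an aromatic carbon. Among the compounds with values here, neither measured step touches this part of the shared core, so no measured step bears directly on the change; both only show that single changes elsewhere on compound 1 cost a great deal of potency. With a larger group entering and no guidance from the measured steps, compound 4 is expected to give 1500 nM, within a range from 300 nM to 10000 nM. This estimate corresponds to an expected step of a 3.4-fold higher number from compound 1 to compound 4 (0.53 log units; beyond the scatter).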

Compound 4, half-maximal inhibitory concentration: 14500 nM
The estimate for compound 4 lay 9.7-fold (0.99 log units) below the measured number; measured number outside the range, above it.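

In this assay, within the data shown here, 1-benzofuran-2-yl in place of thiophen-2-yl gives a 33-fold higher number from compound 1 to compound 4 (1.52 log units; beyond the scatter), so the position carrying this group on the shared core is also sensitive, which the earlier steps, made elsewhere on compound 1, could not show. Compound 4 still gives a real number, so this loss can be sized, whereas compound 2 and compound 3 stop at an assay limit: the limit of > 20000 nM in this assay, at which 2 of the 4 values shown sit. The change is a double one, since the entering group adds a six-membered aromatic ring of carbon only and carries oxygen where the leaving group carries sulfur, and the data cannot say which of the two matters.

Furan-2-yl would test the oxygen alone, and 1-benzothiophen-2-yl the added ring alone. Going by these compounds, how a plain phenyl ring or a small amine would fare at this position also remains open.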